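The compounds below may be only part of what the source reports. "The series", "measured", "known", "first", "only" and "open" are said of these compounds alone.

Compound 1 `CCOC(=O)c1nn(-c2ccccc2)c(-c2ccc(Cl)cc2)c1CNC(C)(C)C` opens the series. In a functional assay on OVCAR-3 cells (Homo sapiens) for inhibition, read by sulforhodamine B assay, with a stated time of 48 h (on this read-out higher numbers stand for weaker inhibition of growth and lower numbers for stronger inhibition of growth), compound 1 gives 134 nM; > 559000 nM (2 entries). The two entries lie far apart, as the several entries of compound 1 in this assay, 134 nM; > 559000 nM (2 entries) shows. Of these entries for compound 1, one is a number and the other is a limit of the assay. Compound 2 `CC(C)(C)NCc1c(C(=O)O)nn(-c2ccccc2)c1-c1ccc(Cl)cc1` shares the core of compound 1. In this assay compound 2 stands at > 652000 nM, which is a limit of the assay and not a number, and a further entry for compound 2 gives no single number either.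

Compound 3 `CC(C)(C)NCc1c(C(=O)O)nn(-c2ccccc2)c1-c1ccccc1` differs from compound 2 in one place: hydrogen in place of chloro on an aromatic carbon. Hydrogen stands in place of chloro on an aromatic carbon, so that 4-chlorophenyl becomes phenyl. Among the measured compounds shown here, no measured step shows what this change does, so no shift beyond the scatter is expected in this assay, in either direction. That expectation rests on compound 2, with its limit of > 652000 nM. For compound 3 the expected value is 600000 nM, with an estimated range from 100000 nM to 1000000 nM. The estimate amounts to an expected at least 1.0-fold lower number from compound 2 to compound 3 (0.03 log units; that floor lies within the scatter).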

Compound 3, concentration for 50% growth inhibition: > 716000 nM
Compound 3: a limit, no number (the forecaster's own chance of this, stated with the estimate: 80%); middle value at least 1.1-fold (0.07 log units) away from the limit.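

In this assay compound 3 gives > 716000 nM, which is a limit of the assay and not a number. Compound 2 stands at > 652000 nM, also a limit, so the step between compound 2 and compound 3 cannot be read. The compounds shown leave open what replacing 4-chlorophenyl with phenyl does to growth inhibition in this assay.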